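This account rests on a few compounds, and the source may have more. Where it says the series, first, only, none or still open, it means among the compounds named here.

Series notes. Compound 1 `COc1ccc2nc(-c3c(Cl)nc(N)nc3N[C@@H]3C[C@H](CO)[C@@H](O)[C@H]3O)sc2c1` and compound 2 `CN(C)c1ccc2nc(-c3c(Cl)nc(N)nc3N[C@@H]3C[C@H](CO)[C@@H](O)[C@H]3O)sc2c1` share the core of compound 1 with a chloro substituent and differ only on the fused ring; compound 3 `Cc1nc(N)nc(N[C@@H]2C[C@H](CO)[C@@H](O)[C@H]2O)c1-c1nc2ccccc2s1` carries a methyl in place of that chloro and an unsubstituted fused ring. In an ADME assay on cells (Homo sapiens) for cytotoxicity, read by polymerase chain reaction, with a stated time of 3 days (a lower number here means that less compound is tolerated, a higher number that more compound is tolerated), compound 1 gives > 25000 nM, which is a limit of the assay and not a number. Compound 2 gives > 25000 nM in this assay, again a limit. Among the compounds with values here, compound 3 is the only member with a read number, giving 4000 nM in this assay, so it alone fixes a point on the scale. Within the data shown here, the single measured step, a step that the two limits leave unreadable from compound 1 to compound 2, is unreadable because of the limit of > 25000 nM in this assay, at which 2 of the 3 values shown sit, and so no readable step exists at all.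

Compound 4 `Cc1nc(NCc2ccccc2)nc(N[C@@H]2C[C@H](CO)[C@@H](O)[C@H]2O)c1-c1nc2ccccc2s1` is the next member. Its change from compound 3 is benzyl in place of hydrogen on a nitrogen on an aromatic ring, the same difference read one bond further out being amino to benzylamino. Among the measured compounds shown here, no measured step touches this nitrogen, and the one step recorded sits on a different ring between two limit values, so nothing here points to a direction for this assay. Compound 4 is therefore expected to land near compound 3, with an estimated 3500 nM in this assay, between 1000 nM and 12000 nM. The expected step is a 1.1-fold lower number from compound 3 to compound 4 (0.06 log units; within the scatter), within the scatter.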

Compound 4, half-maximal cytotoxic concentration: 9000 nM
Compound 4: middle estimate off by 2.6-fold (0.41 log units), on the low side; measured number inside the range.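

The series now has its first readable step, and it sits on the nitrogen on an aromatic ring: in this assay, benzyl in place of hydrogen gives a 2.3-fold higher number from compound 3 to compound 4 (0.35 log units; beyond the scatter). This position therefore accepts an added six-membered aromatic ring of carbon only, and the change moves the read-out towards more compound being tolerated, not less, although the shift is modest and rests on this single pair. None of the information given on the series bears on why the number moves in this direction.

On these data alone, it remains open whether the direction of this step depends on the ring in benzyl or holds for other groups on the same nitrogen, such as a simple methyl, a longer chain like phenethyl, or a benzyl carrying a carboxylic acid or an amine. As far as these compounds go, it is equally open whether the amino to benzylamino change would be readable on the chloro-bearing core of compound 1, since the two values shown for that core are limits of the assay and not numbers.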